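The source may report more compounds than this note shows. Statements on the series, on what has been measured and on what is new or still open speak of the compounds shown alone.

Three compounds were measured in a functional assay on NCI-H1975 cells (Homo sapiens) for inhibition, read by sulforhodamine B assay, tested at 10 uM; a lower number here means less inhibition, a higher number more inhibition at the concentration tested (going by the name of the read-out):

Compound 1, `CC(=O)N1N=C(c2ccc(-n3cncn3)cc2)CC1c1ccc(N(C)C)cc1`: -0.3%
Compound 2, `CN(C)c1ccc(C2CC(c3ccc(-n4cncn4)cc3)=NN2C(=O)CCCl)cc1`: -0.7%
Compound 3, `CN(C)c1ccc(C2CC(c3ccc(-n4cncn4)cc3)=NN2C(=O)c2ccc(F)cc2)cc1`: -1.1%

All three share one core and differ only in the group on the carbonyl carbon. On the bare numbers compound 3 sits at the low end of the three, but the step of a number 0.4 percentage points lower from compound 2 to compound 3 (within the scatter) and the step of a number 0.8 percentage points lower from compound 1 to compound 3 (within the scatter) are both within the scatter, as is a number 0.4 percentage points lower from compound 1 to compound 2 (within the scatter), so the three compounds cannot be told apart: none of them shows inhibition at the concentration tested.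

Compound 4 is `CN(C)c1ccc(C2CC(c3ccc(-n4cncn4)cc3)=NN2C(=O)c2ccc(C(F)(F)F)cc2)cc1`. It differs from compound 3 by trifluoromethyl in place of fluoro on an aromatic carbon, so the change again sits on the group attached to the carbonyl carbon, this time on the aromatic ring of the (4-fluorophenyl)carbonyl unit. The three measured steps all bear on this region, and all three were within the scatter. For the measured compounds named here, no measured step swaps a fluoro for a trifluoromethyl, so that particular change is untested here. Since every earlier change at the carbonyl carbon left the read-out unchanged, compound 4 is expected to behave like compound 3, with a step of a number 0.1 percentage points higher from compound 3 to compound 4 (within the scatter) that stays within the scatter. Compound 4 is therefore estimated at -1%, in a range from -10% to 8%.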

Compound 4, a percentage reported as inhibition, at one concentration (the size of the read-out at that concentration, not a potency): 11.5%
Beside the measured number, compound 4's estimate is 12.5 percentage points below it; measured number above the stated range.
By their numbers in this assay, from the lowest: compounds 3, 2 and 1 (each within the scatter of the next); then compound 4.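

In this assay, the substituent on the aromatic ring of the group attached to the carbonyl carbon proves able to move the read-out: trifluoromethyl in place of fluoro gives the step (a number 12.6 percentage points higher from compound 3 to compound 4 (beyond the scatter)), the first here to clear the scatter. Compound 4 also stands apart from the compounds carrying other groups on the carbonyl carbon, with the steps (a number 12.2 percentage points higher from compound 2 to compound 4 (beyond the scatter)) and (a number 11.8 percentage points higher from compound 1 to compound 4 (beyond the scatter)), so among these four only the 4-(trifluoromethyl)phenyl group separates from the rest, and it does so modestly, at a single concentration. Nothing available here accounts for why this one exchange registers when the earlier ones did not.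

The compounds shown leave open whether the gain is particular to trifluoromethyl or would also appear with another group at the same ring carbon, such as a nitrile, a methoxy group or a carboxylic acid. They also leave open whether compound 4 would show a graded response across concentrations, and whether changes elsewhere on the shared core would add to this step.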